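Second chloro on the aryl ketone of the hydroxamate series

This account rests on a few compounds, and the source may have more. Where it says the series, first, only, none or still open, it means among the compounds named here.

Compound 1 `O=C(/C=C/c1ccc(/C=C/C(=O)c2cccc(Cl)c2)o1)NO` stands lowest of the two numbers recorded in an assay on isolated protein for inhibition of histone deacetylase 4 (Homo sapiens), read by fluorescence; on this read-out higher numbers stand for weaker inhibition and lower numbers for stronger inhibition; in this assay compound 1 gives 12900 nM. Its nearest neighbour is compound 2 `O=C(/C=C/c1ccc(/C=C/C(=O)c2ccccc2)o1)NO`, which in this assay gives 22800 nM; the step of a 1.8-fold higher number from compound 1 to compound 2 (0.25 log units; within the scatter) is hydrogen in place of chloro on an aromatic carbon, so the two values cannot be ordered.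

Compound 3 `O=C(/C=C/c1ccc(/C=C/C(=O)c2cc(Cl)ccc2Cl)o1)NO` differs from compound 1 by chloro in place of hydrogen on an aromatic carbon. Among the compounds with values here, the only step that bears on this change is the one from compound 1 to compound 2, where removing the single chloro moved the number by a 1.8-fold higher number from compound 1 to compound 2 (0.25 log units; within the scatter), a shift inside the scatter. Within the data shown here, a second chloro on the same ring therefore has no measured precedent that points to a change of real size in this assay, in either direction, and the working expectation is a number close to that of compound 1.

Compound 3 is accordingly estimated at 12000 nM in this assay, with a range of 5000 nM to 30000 nM, corresponding to an expected step of a 1.1-fold lower number from compound 1 to compound 3 (0.03 log units; within the scatter).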

Compound 3, half-maximal inhibitory concentration: 4310 nM
Compound 3: middle estimate off by 2.8-fold (0.44 log units), on the high side; the measured number lies below the stated range.
By their numbers in this assay, from the lowest: compound 3; then compounds 1 and 2 (each within the scatter of the next).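

Chloro in place of hydrogen on this aromatic carbon, ortho to a large group and para to a chloro group, gives a 3.0-fold lower number from compound 1 to compound 3 (0.48 log units; beyond the scatter) in this assay, a modest step but one that can be read as real. Within the data shown here, the only earlier step on this ring, a 1.8-fold higher number from compound 1 to compound 2 (0.25 log units; within the scatter), stayed within the scatter and could not be ordered, so this carbon provides the first readable change on the aryl ketone ring and shows that the number can fall when a chloro is added to the ring of compound 1. No measurement at hand explains the size of this step or says why the number falls.

On these data alone, it remains open whether this chloro would give a step of similar size without the chloro group para to it, since the step is read only on the ring of compound 1, which already carries that group. Also open, as far as these compounds go, is whether a fluoro, a methyl, a methoxy or an amine on the same aromatic carbon would lower the number as this chloro does, or would leave it unchanged.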